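Trimming the long chain of compound 3

The source may report more compounds than this note shows. Statements on the series, on what has been measured and on what is new or still open speak of the compounds shown alone.

In a functional assay on CHO cells (Cricetulus griseus) for inhibition (on this read-out higher numbers stand for weaker inhibition and lower numbers for stronger inhibition), compound 3 `CCCCCCCCCCCCCCCCCC(=O)N[C@@H](CO)C[C@@H](O)c1ccccc1` gives > 1000 nM as its reading, which is a limit and not a number. Compound 1 `CCCCCCCCCCCC(=O)N[C@@H](CO)C[C@@H](O)c1ccccc1` shows 70 nM and compound 2 `CCCCCCCCCCCCCC(=O)N[C@@H](CO)C[C@@H](O)c1ccccc1` shows 70 nM on the same read-out. Compound 4 `CCCCCCCCCCCCC(=O)N[C@@H](CO)C[C@@H](O)c1ccccc1` carries hydrogen in place of pentyl on a saturated chain carbon, ten or more bonds along the chain from a carbonyl carbon. Within the data shown here, two measured steps bear most directly on this, and both were large: an at least 14-fold higher number from compound 1 to compound 3 (1.15 log units; beyond the scatter) and an at least 14-fold higher number from compound 2 to compound 3 (1.15 log units; beyond the scatter) (each beyond the scatter). The third, no change at the digits printed from compound 1 to compound 2 (within the scatter) (within the scatter), involved no such loss. Running those large steps backwards suggests a large move towards stronger inhibition, so the expected step is an at least 14-fold lower number from compound 3 to compound 4 (1.15 log units; beyond the scatter) (an estimate). In this assay compound 4 is expected at 70 nM (estimated range 35 nM to 160 nM).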

Compound 4, half-maximal inhibitory concentration: 50 nM
Estimate against measurement, compound 4: 1.4-fold (0.15 log units) above, within the range that was stated.
By their numbers in this assay, from the lowest: compounds 4, 1 and 2 (each within the scatter of the next). At a limit, above all of these: compound 3.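

In this assay, taking pentyl off the long chain gives an at least 20-fold lower number from compound 3 to compound 4 (1.30 log units; beyond the scatter), so the large loss seen with compound 3 is undone by this one change. Methyl in place of hydrogen gives a 1.4-fold lower number from compound 1 to compound 4 (0.15 log units; within the scatter), and hydrogen in place of methyl gives a 1.4-fold lower number from compound 2 to compound 4 (0.15 log units; within the scatter); both are within the scatter, so compounds 1, 2 and 4 read alike despite their different chain lengths. Compound 3 stands at a limit and not at a number: the limit of > 1000 nM in this assay, at which 1 of the 4 values shown sits.

Where the loss sets in on the way from compound 2 to compound 3 stays open. So does whether a much shorter chain, or a chain carrying an amine or a carboxylic acid, would keep this inhibition.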